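This account rests on a few compounds, and the source may have more. Where it says the series, first, only, none or still open, it means among the compounds named here.

Compound 1 `CCCCCCCCCCCC(=O)OCCc1ccc(O)cc1`: 67200 nM
Compound 2 `CCCCCCCCCC(=O)OCCc1ccc(O)cc1`: 172000 nM

In a toxicity assay on MRC5 cells (Homo sapiens) for inhibition, read by MTT assay, with a stated time of 72 h (on this read-out lower numbers stand for stronger inhibition and higher numbers for weaker inhibition), compound 2 gives 172000 nM, the higher of the two numbers and so the weaker inhibition. Within the data shown here, the only measured step, a 2.6-fold higher number from compound 1 to compound 2 (0.41 log units; beyond the scatter), comes from a change in the saturated chain. Compound 3 `CCCCCCCCCC(=O)OCCc1ccc(O)c(O)c1` keeps the chain of compound 2 and changes the aromatic ring instead: hydroxy in place of hydrogen on an aromatic carbon. Among the measured compounds shown here, no measured compound shows what such a ring change does, so the data give no direct guide to its direction. The chain step of a 2.6-fold higher number from compound 1 to compound 2 (0.41 log units; beyond the scatter) serves only as a rough gauge of how far this assay can move within this small set. A modest move toward stronger inhibition is therefore a tentative expectation. The expected step is a 1.9-fold lower number from compound 2 to compound 3 (0.28 log units; within the scatter), and its uncertainty is wide. For compound 3 the estimated value is 90000 nM, with an expected range from 30000 nM to 200000 nM.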

Compound 3, half-maximal inhibitory concentration: 71100 nM
Estimate against measurement, compound 3: 1.3-fold (0.10 log units) above; low and high end bracket the measured number.
By their numbers in this assay, from the lowest: compounds 1 and 3 (each within the scatter of the next); then compound 2.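

In this assay, adding a hydroxy group to the aromatic carbon ortho to the existing hydroxy group and meta to the large group gives a 2.4-fold lower number from compound 2 to compound 3 (0.38 log units; beyond the scatter). Among these compounds, this is the first measured change on the ring rather than the saturated chain, and it shows that this position can also shift the number, here toward stronger inhibition by a modest step. Nothing available explains this shift.

Going by these compounds, it remains open whether a different group at this position, such as a methoxy group, an amine or a fluorine atom, would shift the number in the same direction. On these data alone, it is also open whether the same hydroxy change would give a step of similar size on the longer chain of compound 1.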